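A few compounds are considered here, and "the series" means these few. Any claim that something is new, unique, unknown or untested is made for them only; others in the source may bear on it.

Two related compounds have been tested in a functional assay on Doay cells (Homo sapiens) for cytotoxicity, read by MTT assay; a lower number here means that less compound is needed, a higher number that more compound is needed for the effect. Compound 1 (`C=C1C(=O)O[C@]2(C)CC[C@@H]1C[C@H](O)[C@@]1(C)CC[C@H](O1)[C@](C)(O)CC[C@H]2O`) gives < 20 ug/mL, which is a limit of the assay and not a number. Compound 2 (`C=C1C(=O)O[C@]2(C)CC[C@@H]1C[C@H](O)[C@@]1(C)CC[C@H](O1)[C@](C)(O)CCC2=O`) gives < 20 ug/mL, again a limit and not a number. Compound 2 therefore has no exact position, and the record shows only (the limit of < 20 ug/mL in this assay, at which 2 of the 2 values shown sit). Compound 3 (`C=C1C(=O)O[C@]2(C)CC[C@@H]1C[C@H](OC(C)=O)[C@@]1(C)CC[C@H](O1)[C@](C)(O)CCC2=O`) departs from compound 2 by one change, hydroxy to acetoxy, with acetyl in place of hydrogen on an oxygen on a saturated carbon. Among the measured compounds shown here, no measured pair shows what this change does in this assay, so no step beyond the scatter is expected, and no direction is predicted with confidence. The expected step is a step that the limit leaves unreadable from compound 2 to compound 3. Compound 3 is estimated at 12 ug/mL, with an expected range of 3 ug/mL to 30 ug/mL.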

Compound 3, concentration for half-maximal effect: < 20 ug/mL
Compound 3: no number, only a limit; the forecaster's own chance of this, stated with the estimate: 45%; the middle value lies beyond the limit too.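

In this assay, among the compounds shown here, compound 3 gives < 20 ug/mL as a limit of the assay and not a number, so no step from compound 2 to compound 3 can be read: the limit of < 20 ug/mL in this assay, at which 3 of the 3 values shown sit. The compounds shown leave open the exact values and whether hydroxy to acetoxy changes the effect at all.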